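This account rests on a few compounds, and the source may have more. Where it says the series, first, only, none or still open, it means among the compounds named here.

Three ureas built on the same core have been measured in a functional assay on NCI-H520 cells (Homo sapiens) for inhibition, read by MTT assay, with a stated time of 48 h, tested at 10 uM; on this read-out lower numbers stand for less inhibition and higher numbers for more inhibition at the one concentration tested (going by the name of the read-out). Compound 1 `COc1cc(NC(=O)Nc2cc(Nc3ccc(C(C)(C)C)cc3)ncn2)cc(OC)c1` gives 17.5%. Compound 2 `CCc1ccc(Nc2cc(NC(=O)Nc3cc(OC)cc(OC)c3)ncn2)cc1` gives 23.5%. Compound 3 `COc1ccc(F)cc1Nc1cc(NC(=O)Nc2c(Cl)cccc2Cl)ncn1` gives 38.1%. Among these three numbers compound 2 stands second highest; its nearest neighbour is compound 1, which lies lower by an amount within the scatter, while compound 3 lies higher than compound 2 by a gap beyond the scatter.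

Compound 4 `COc1cc(NC(=O)Nc2cc(Nc3ccc(C)c(C)c3)ncn2)cc(OC)c1` has not yet been measured. It differs from compound 2 in one place: 3,4-dimethylphenyl in place of 4-ethylphenyl on a nitrogen on an aromatic ring.

Among the compounds with values here, only one measured step bears on this change. From compound 1 to compound 2 the substituent on the same aromatic ring was altered, and the result was a number 6 percentage points higher from compound 1 to compound 2 (within the scatter). Within the data shown here, compound 3 differs from compound 2 in more than one place, so it offers no single step to lean on. Among the measured compounds shown here, the change from compound 2 to compound 4 keeps the same atoms and only rearranges them, and the one comparable step stayed within the scatter, so no step beyond the scatter is expected in this assay, in either direction.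

Compound 4 is therefore expected to give 24%, with a range from 12% to 38%. This estimate means a step of a number 0.5 percentage points higher from compound 2 to compound 4 (within the scatter), which is expected to fall within the scatter.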

Compound 4, a percentage reported as inhibition, at one concentration (the size of the read-out at that concentration, not a potency): 29.5%
Compound 4: the middle estimate sits 5.5 percentage points below what was measured, within the range that was stated.
By their numbers in this assay, from the lowest: compounds 1, 2, 4 and 3 (each within the scatter of the next, the first and the last beyond it).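

In this assay, rearranging the same carbon atoms from 4-ethylphenyl to 3,4-dimethylphenyl on the nitrogen gives a number 6 percentage points higher from compound 2 to compound 4 (within the scatter) and so shows no clear effect of this rearrangement. Within the data shown here, the wider comparison adds something new: 3,4-dimethylphenyl in place of 4-(tert-butyl)phenyl gives a number 12 percentage points higher from compound 1 to compound 4 (beyond the scatter) and is the first single-place change at this position to clear the scatter, although only modestly, while compound 2 remains within the scatter of both neighbours, so the series separates its two ends without forming a graded order. No measurement offered here accounts for that difference.

On these data alone, the three compounds compared at this position carry only alkyl groups on the phenyl ring, so it remains open how a hydroxyl, a primary amine or a carboxylic acid there would read in this assay on the same core. Compound 3 differs from the others in more than one place, which leaves open how much of its number belongs to the 2,6-dichlorophenyl urea and how much to the ring on the nitrogen.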